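This account rests on a few compounds, and the source may have more. Where it says the series, first, only, none or still open, it means among the compounds named here.

Compound 3 `Cc1cccc2c1N(CC(=O)O)C/C(=C\c1ccc(F)cc1)C2=O` sits in the middle of three measured compounds. In an assay on HL-60 cells for inhibition of glutathione S-transferase P (Homo sapiens), read by spectrophotometry, tested at 20 uM (a higher number here means more inhibition at the concentration tested (going by the name of the read-out), a lower number less inhibition), compound 3 gives 22.9%. Compound 1 `COc1ccccc1/C=C1\CN(CC(=O)O)c2c(C)cccc2C1=O` gives 4.72% in this assay, and compound 2 `CCOc1ccc(/C=C2\CN(CC(=O)O)c3c(C)cccc3C2=O)cc1` gives 42.4%. The two steps that lead to compound 3 are both modest: a number 18.2 percentage points higher from compound 1 to compound 3 (beyond the scatter), and a number 19.5 percentage points lower from compound 2 to compound 3 (beyond the scatter).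

Compound 4 `Cc1ccc(/C=C2\CN(CC(=O)O)c3c(C)cccc3C2=O)cc1` is not yet measured. It differs from compound 3 in one place: methyl in place of fluoro on an aromatic carbon. Going by the values given here, the step that bears most directly on this change is the one from compound 2 to compound 3, since it swaps the group on the same aromatic carbon, ethoxy for fluoro, and moved the number by a modest amount. Among the compounds with values here, no measured step shows methyl at this position, so the size of the effect of methyl is unknown; a small group replaces another small group, and a step no larger than the modest ones seen is expected, in either direction.

The estimate for compound 4 in this assay is 28%, with an expected range from 12% to 48%. The expected step is a number 5.1 percentage points higher from compound 3 to compound 4 (within the scatter).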

Compound 4, a percentage reported as inhibition, at one concentration (the size of the read-out at that concentration, not a potency): 46.8%
Beside the measured number, compound 4's estimate is 18.8 percentage points below it; the range from low to high includes it.
By their numbers in this assay, from the lowest: compound 1; then compound 3; then compounds 2 and 4 (each within the scatter of the next).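

Swapping fluoro for methyl gives a number 23.9 percentage points higher from compound 3 to compound 4 (beyond the scatter) in this assay even though each group counts one heavy atom and neither has a hydrogen-bond donor or acceptor, so heavy-atom count alone does not set the number here. Methyl and ethoxy cannot be told apart at this position (a number 4.4 percentage points higher from compound 2 to compound 4 (within the scatter)), which leaves compound 3 with fluoro below both. Replacing 2-methoxyphenyl with 4-methylphenyl gives a number 42.1 percentage points higher from compound 1 to compound 4 (beyond the scatter) and the data offer no measured explanation for any of these steps.

The compounds shown leave open whether an amine, a hydroxyl or a longer chain such as butoxy at this position would give a number nearer that of compound 3 or that of compound 4. They also leave open whether the low number of compound 1 comes from the methoxy group itself or from where it sits on the ring.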